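The source may report more compounds than this note shows. Statements on the series, on what has been measured and on what is new or still open speak of the compounds shown alone.

The measured compounds:
Compound 1, `C/C=C/C(=O)Nc1cccc(-c2nc3ccccc3s2)c1`: in an ADME assay on BJ cells (Homo sapiens) for inhibition, with a stated time of 72 h (a higher number here means that more compound is needed for the effect, a lower number that less compound is needed), compound 1 gives > 25000 nM, which is a limit of the assay and not a number.
Compound 2, `O=C(Nc1cccc(-c2nc3ccccc3s2)c1)c1ccc(Cl)nc1Cl`: in this assay compound 2 gives > 25000 nM, which is likewise a limit.

The two compounds share a core and differ only in the group on the carbonyl carbon. The step from compound 1 to compound 2 in this assay is a step that the two limits leave unreadable from compound 1 to compound 2, so its size cannot be read. Compound 2 thus stands on a limit rather than on a number, as the limit of > 25000 nM in this assay, at which 2 of the 2 values shown sit, shows.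

The unmeasured compound 3, `O=C(Nc1cccc(-c2nc3ccccc3s2)c1)c1ccnc(Cl)c1`, differs from compound 2 in one place: 2-chloropyridin-4-yl in place of 2,6-dichloropyridin-3-yl on a carbonyl carbon. Among the measured compounds shown here, the only measured step on this carbonyl group, from compound 1 to compound 2, is unreadable, so no measured change gives a direction or size for the step to compound 3. With compound 1 and compound 2 both at the limit, compound 3 is expected to sit near that limit again, an expected step that the limit leaves unreadable from compound 2 to compound 3. The estimate for compound 3 in this assay is 30000 nM, with a range from 8000 nM to 100000 nM.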

Compound 3, half-maximal effective concentration: > 25000 nM
Compound 3: only a limit was reported; the forecaster's own chance of this, stated with the estimate: 70%; the middle value lies beyond the limit too.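

In this assay compound 3 gives > 25000 nM as a limit of the assay and not a number. Among the compounds shown here, no step among compound 1, compound 2 and compound 3 can be read, and no size can be given for any of them: the limit of > 25000 nM in this assay, at which 3 of the 3 values shown sit. The compounds shown leave open how much of each compound the effect would need, and whether the group on the carbonyl carbon changes that amount.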